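This account rests on a few compounds, and the source may have more. Where it says the series, first, only, none or still open, it means among the compounds named here.

Working notes on the series. In a functional assay on HT-29 cells (Homo sapiens) for cytotoxicity, read by MTT assay, with a stated time of 6 days (on this read-out higher numbers stand for an effect only at larger amounts of compound and lower numbers for an effect already at smaller amounts), compound 1 (`COC(=O)c1c(-c2ccc([N+](=O)[O-])cc2)oc2cc(OC)ccc2c1=O`) gives > 25 ug/mL as a limit of the assay. Compound 2 (`COC(=O)c1c(-c2ccc(N)cc2)oc2ccccc2c1=O`) gives > 25 ug/mL as a limit as well. Compound 3 (`COc1cc(-c2cc(=O)c3ccc(O)cc3o2)cc(OC)c1OC`) gives > 25 ug/mL as a limit too. All three stand at the same place (the limit of > 25 ug/mL in this assay, at which 3 of the 3 values shown sit) and offer no number to step from. Compound 4 (`COc1cc(-c2cc(=O)c3ccc(O)c(O)c3o2)cc(OC)c1OC`) differs from compound 3 by one change (hydroxy in place of hydrogen on an aromatic carbon), hydroxy in place of hydrogen on an aromatic carbon. Within the data shown here, no measured step in this assay gauges this change, so only a small move toward lower numbers is expected, possibly none beyond the scatter. The estimate means an at least 1.2-fold lower number from compound 3 to compound 4 (0.09 log units; that floor lies within the scatter) as an expected change. For compound 4 the estimated value is 20 ug/mL with an expected range from 8 ug/mL to 40 ug/mL on this read-out.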

Compound 4, concentration for half-maximal effect: 3.66 ug/mL
The estimate for compound 4 lay 5.5-fold (0.74 log units) above the measured number; measured number below the stated range.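

Among these compounds, compound 4 is the only compound here in this assay that gives a number rather than a limit, so this aromatic carbon, ortho to a hydroxy group and ortho to a fused ring, is a place where a change shifts the read-out. Hydroxy in place of hydrogen there gives an at least 6.8-fold lower number from compound 3 to compound 4 (0.83 log units; beyond the scatter). This step is only a floor, and the other compounds offer no number to compare it with: the limit of > 25 ug/mL in this assay, at which 3 of the 4 values shown sit.

From the compounds shown here alone, whether a fluorine or a carboxylic acid at this place would give a similar step stays open. So does whether the step depends on the hydroxy group already present in compound 3.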